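A few compounds are considered here, and "the series" means these few. Any claim that something is new, unique, unknown or untested is made for them only; others in the source may bear on it.

Compound 1 `O=C(NCc1cn(Cc2ccc(C(F)(F)F)cc2)nn1)c1cn(-c2ccccc2)nc1-c1ccccc1` in a functional assay on MIA PaCa-2 cells (Homo sapiens) for antiproliferative activity, read by sulforhodamine B assay, with a stated time of 48 h; a higher number here means a weaker inhibitor of growth, a lower number a stronger inhibitor of growth: 17700 nM
Compound 2 `O=C(NCc1cn(Cc2ccc(Cl)cc2)nn1)c1cn(-c2ccccc2)nc1-c1ccc(F)cc1` in this assay: 280 nM

Compound 2 stands at the lowest of the two numbers in this assay; compound 1 sits far higher, a gap beyond the scatter, though the two structures differ in two places at once. Compound 3 `O=C(NCc1cn(Cc2ccc(C(F)(F)F)cc2)nn1)c1cn(-c2ccccc2)nc1-c1ccc(F)cc1`, not yet measured, carries trifluoromethyl in place of chloro on an aromatic carbon. Compound 1 also bears the trifluoromethyl group but lacks the fluoro on the other ring, so how much of its gap belongs to each change cannot be told. The expected step is a 5.4-fold higher number from compound 2 to compound 3 (0.73 log units; beyond the scatter), upward and probably beyond the scatter. Compound 3 is estimated at 1500 nM, between 300 nM and 8000 nM.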

Compound 3, concentration for 50% growth inhibition: 760 nM
Compound 3: the middle estimate sits 2.0-fold (0.30 log units) above what was measured, and the stated range covers the measured number.
By their numbers in this assay, from the lowest: compound 2; then compound 3; then compound 1.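

In this assay, trifluoromethyl in place of chloro on an aromatic carbon gives a 2.7-fold higher number from compound 2 to compound 3 (0.43 log units; beyond the scatter), so this position tolerates the larger group with only a modest change. Fluoro in place of hydrogen on an aromatic carbon gives a 23-fold lower number from compound 1 to compound 3 (1.37 log units; beyond the scatter), so of the two changes separating compound 1 from compound 2, the fluoro carries the larger step. Nothing available explains either step. As far as these compounds go, whether the fluoro step holds with chloro on the benzyl group stays open, as does the effect of a methoxy group or an amine at the chloro position.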